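Swapping trifluoromethyl for trifluoromethoxy on an amide-bearing ring

This account rests on a few compounds, and the source may have more. Where it says the series, first, only, none or still open, it means among the compounds named here.

Measured compounds:
- compound 1, `CS(=O)(=O)c1ccc(C(=O)N2CCC(N(C3CC3)S(=O)(=O)c3cccc(C(F)(F)F)c3)CC2)c(OC(F)(F)F)c1`: 48 nM
- compound 2, `NC(=O)c1ccc(C(=O)N2CCC(N(C3CC3)S(=O)(=O)c3cccc(C(F)(F)F)c3)CC2)c(C(F)(F)F)c1`: 760 nM

Both were tested in an assay on HEK293 cells for inhibition of Voltage-dependent N-type calcium channel subunit alpha-1B (Homo sapiens), read by FLIPR and calcium flux; a lower number here means a stronger inhibitor, a higher number a weaker inhibitor. Compound 1 gives 48 nM, whereas compound 2 gives 760 nM, the higher of the two numbers, and the gap between them is beyond the usual scatter. Among the compounds with values here, compound 1 and compound 2 differ in two places at once, so no single step between them can be read from these numbers.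

Compound 3, `NC(=O)c1ccc(C(=O)N2CCC(N(C3CC3)S(=O)(=O)c3cccc(C(F)(F)F)c3)CC2)c(OC(F)(F)F)c1`, has not yet been measured. It is compound 2 with one change: trifluoromethoxy in place of trifluoromethyl on an aromatic carbon. With this change compound 3 takes on the trifluoromethoxy group that compound 1 carries, while keeping the carbamoyl group of compound 2. Within the data shown here, since compound 1 gives the lower number, 48 nM, and compound 2 the higher, 760 nM, a move partway toward compound 1 is expected to lower the number somewhat, though with only two compounds this expectation is loose. The expected step is a 3.0-fold lower number from compound 2 to compound 3 (0.48 log units; beyond the scatter). In this assay compound 3 is expected to give 250 nM, with a likely range from 70 nM to 900 nM.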

Compound 3, half-maximal inhibitory concentration: 390 nM
For compound 3 the middle estimate is 1.6-fold (0.19 log units) below the measured one, and the stated range covers the measured number.
By their numbers in this assay, from the lowest: compound 1; then compounds 3 and 2 (each within the scatter of the next).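

In this assay, putting trifluoromethoxy in place of trifluoromethyl on this aromatic carbon, with the carbamoyl group held constant, gives a 1.9-fold lower number from compound 2 to compound 3 (0.29 log units; within the scatter), so this change does not separate the two groups here. With trifluoromethoxy held constant, the other single change, carbamoyl in place of methylsulfonyl, gives an 8.1-fold higher number from compound 1 to compound 3 (0.91 log units; beyond the scatter), making it the only one of the two readable steps that lies beyond the scatter. No measurement shown offers an explanation for either result.

Going by these compounds, the trifluoromethoxy-for-trifluoromethyl step has been read only with carbamoyl on the ring, so it remains open whether the same swap would also fall within the scatter with methylsulfonyl there. Also open, on these data alone, is how other groups would read at these two aromatic carbons, such as a nitrile or a carboxylic acid in place of carbamoyl, or a chlorine or a methoxy group in place of trifluoromethoxy.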